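Replacing a pyrazole with a cyanopyridine on the shared core

The source may report more compounds than this note shows. Statements on the series, on what has been measured and on what is new or still open speak of the compounds shown alone.

Measured compounds:
- compound 1 `CCC(C)(C)Cc1c[nH]c(CCc2ccc(-n3cccn3)cc2)n1`: 135 nM
- compound 2 `CCC(C)(C)Cc1c[nH]c(CCc2ccc(-n3ccnn3)cc2)n1`: 641 nM

In a functional assay on HEK293 cells for agonist activity at Bombesin receptor subtype-3 (Homo sapiens), read by luminescence and calcium flux, with a stated time of 10 min (a lower number here means that less compound is needed, a higher number that more compound is needed for the effect), compound 1 gives 135 nM, the lowest of the two numbers available. For the measured compounds named here, the only other measured compound is compound 2, and the step of a 4.7-fold higher number from compound 1 to compound 2 (0.68 log units; beyond the scatter) shows that swapping one small five-membered ring for another on this aromatic carbon already moves the number noticeably.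

Compound 3 `CCC(C)(C)Cc1c[nH]c(CCc2ccc(-c3cccc(C#N)n3)cc2)n1` differs from compound 1 by 6-cyanopyridin-2-yl in place of 1H-pyrazol-1-yl on an aromatic carbon. Going by the values given here, no measured step involves a six-membered ring or a nitrile at this position, so the step from compound 1 to compound 2 is the only guide, and it bears on the change only loosely: it tells that this position is sensitive, not in which direction a larger group will push.

Compound 3 is therefore expected to land near compound 1 or somewhat weaker, a step of a 1.9-fold higher number from compound 1 to compound 3 (0.27 log units; within the scatter), with an estimated value of 250 nM and a likely range from 60 nM to 1000 nM.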

Compound 3, half-maximal effective concentration: 193 nM
Compound 3: the middle estimate sits 1.3-fold (0.11 log units) above what was measured, and the stated range covers the measured number.
By their numbers in this assay, from the lowest: compounds 1 and 3 (each within the scatter of the next); then compound 2.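

In this assay the step of a 1.4-fold higher number from compound 1 to compound 3 (0.16 log units; within the scatter) shows that this place on the aromatic ring, para to a large group, accepts a six-membered aromatic ring carrying a nitrile as well as a five-membered ring, even though 6-cyanopyridin-2-yl has more heavy atoms than 1H-pyrazol-1-yl. The step of a 3.3-fold lower number from compound 2 to compound 3 (0.52 log units; beyond the scatter) places 6-cyanopyridin-2-yl clearly apart from 1H-1,2,3-triazol-1-yl, so ring size alone does not order these three compounds. Nothing given here explains these numbers.

The compounds shown leave open whether the nitrile matters on its own, or whether the pyridine ring would do as well without it. They also leave open what a plain phenyl ring, a methoxy group or an amine would give at this place.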